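This account rests on a few compounds, and the source may have more. Where it says the series, first, only, none or still open, it means among the compounds named here.

Compound 1 `Oc1ccccc1-c1cc(-c2ccccc2F)cc(-c2ccccc2O)n1` carries a 2-fluorophenyl group and two 2-hydroxyphenyl groups on its core. In a functional assay on T47D cells (Homo sapiens) for inhibition (on this read-out lower numbers stand for stronger inhibition and higher numbers for weaker inhibition), compound 1 gives only a limit, > 50000 nM. Compound 2 `Oc1ccccc1-c1cc(-c2cccc(F)c2)cc(-c2ccccc2O)n1` differs from compound 1 by 3-fluorophenyl in place of 2-fluorophenyl on an aromatic carbon. In this assay compound 2 gives only a limit, > 50000 nM. The step that the two limits leave unreadable from compound 1 to compound 2 can therefore not be read. Two of the three values here are only (the limit of > 50000 nM in this assay, at which 2 of the 3 values shown sit). Compound 3 `Oc1cccc(-c2cc(-c3ccccc3F)cc(-c3cccc(O)c3)n2)c1` has a different core; how the two cores differ is not broken down here. In this assay compound 3 gives 4370 nM, the only number among these values. Compound 4 `Oc1cccc(-c2cc(-c3cccc(F)c3)cc(-c3cccc(O)c3)n2)c1` differs from compound 3 by 3-fluorophenyl in place of 2-fluorophenyl on an aromatic carbon, the same kind of change as that from compound 1 to compound 2, but here the place is meta to two 3-hydroxyphenyl groups rather than two 2-hydroxyphenyl groups. The step from compound 3 to compound 4 is expected to be a 1.0-fold higher number from compound 3 to compound 4 (0.01 log units; within the scatter), an expectation that rests on compound 3 giving 4370 nM and on the earlier step that the two limits leave unreadable from compound 1 to compound 2 being unreadable, so the swap is taken as leaving the value roughly unchanged. Compound 4 is thus estimated at 4500 nM, between 1500 nM and 15000 nM.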

Compound 4, half-maximal inhibitory concentration: 21300 nM
Compound 4: middle estimate off by 4.7-fold (0.68 log units), on the low side; measured number above the stated range.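

In this assay, 3-fluorophenyl in place of 2-fluorophenyl gives a 4.9-fold higher number from compound 3 to compound 4 (0.69 log units; beyond the scatter), so on the core with two 3-hydroxyphenyl groups this swap weakens inhibition by more than the usual scatter. The same swap cannot be read on the core with two 2-hydroxyphenyl groups, because compound 1 and compound 2 give only limits, not numbers: the limit of > 50000 nM in this assay, at which 2 of the 4 values shown sit. The result therefore describes one core only, and it neither confirms nor rules out that the change has the same effect on the other.

The compounds shown leave open how an amine or a carboxylic acid in place of the fluorine would behave on either core. They also leave open whether this swap keeps its size on any further core.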